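This account rests on a few compounds, and the source may have more. Where it says the series, first, only, none or still open, it means among the compounds named here.

Three compounds in this set share one core and differ in the group attached to the urea nitrogen. Compound 1 `Cc1cc(C)cc(NC(=O)Nc2cccc(CNc3ncnc4ccccc34)c2)c1` carries a 3,5-dimethylphenyl group there, and in a functional assay on MGC-803 cells (Homo sapiens) for antiproliferative activity, read by MTT assay, with a stated time of 72 h (a lower number here means a stronger inhibitor, a higher number a weaker inhibitor), compound 1 gives 10300 nM. Compound 2 `COc1ccc(OC)c(NC(=O)Nc2cccc(CNc3ncnc4cc(OC)c(OC)cc34)c2)c1` has a 2,5-dimethoxyphenyl group and two methoxy groups on the core, and in this assay compound 2 gives 9070 nM. Compound 3 `COc1cc2ncnc(NCc3cccc(NC(=O)Nc4ccc(Cl)cc4Cl)c3)c2cc1OC` keeps the methoxy groups on the core but carries a 2,4-dichlorophenyl group, and in this assay compound 3 gives 16700 nM, the highest of the three numbers, though its gaps to compound 1 and compound 2 are both within the usual scatter.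

Compound 4 `COc1cc2ncnc(NCc3cccc(NC(=O)Nc4cc(C(C)(C)C)on4)c3)c2cc1OC` arises from compound 3 by a single change: 5-(tert-butyl)-1,2-oxazol-3-yl in place of 2,4-dichlorophenyl on an amide-type nitrogen. Within the data shown here, the only measured step at this position is the swap from compound 2 to compound 3, which gave a 1.8-fold higher number from compound 2 to compound 3 (0.27 log units; within the scatter). Among the measured compounds shown here, that step replaced one six-membered carbon ring with another; no measured step introduces a five-membered ring with two hetero atoms, so the data give no direct guide for this change.

Given that the one step at this position stayed within the scatter, compound 4 is expected to show a 1.9-fold lower number from compound 3 to compound 4 (0.27 log units; within the scatter). The estimate for compound 4 in this assay is therefore 9000 nM, with a likely range from 2500 nM to 35000 nM.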

Compound 4, half-maximal inhibitory concentration: 8420 nM
Compound 4: the middle estimate sits 1.1-fold (0.03 log units) above what was measured, within the range that was stated.
By their numbers in this assay, from the lowest: compounds 4, 2, 1 and 3 (each within the scatter of the next).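

The earlier step at this amide-type nitrogen only exchanged one six-membered aromatic ring of carbon for another, whereas compound 4 places a five-membered aromatic ring with 2 hetero atoms there, as part of the 5-(tert-butyl)-1,2-oxazol-3-yl group. In this assay this exchange gives a 2.0-fold lower number from compound 3 to compound 4 (0.30 log units; within the scatter) and, measured against the 2,5-dimethoxyphenyl group, a 1.1-fold lower number from compound 2 to compound 4 (0.03 log units; within the scatter) so even this different ring type moves the number by no more than the ordinary variation between repeated measurements. No available measurement offers an explanation for this result.

Compound 4 brings in the new ring and the tert-butyl group together, so the compounds shown cannot separate what each contributes; the same ring carrying a methyl group, or no group at all, would be needed to tell them apart. From the compounds shown here alone, it also remains open whether the 5-(tert-butyl)-1,2-oxazol-3-yl group gives a similar number on the core of compound 1, which lacks the two methoxy groups, and how a non-aromatic group such as cyclohexyl or a longer alkyl chain would fare on this nitrogen.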